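Fluoro in place of hydrogen on a urea-capped phenyl ring

The source may hold more compounds than are shown below. What is called first, only, known or untested is meant among the compounds shown, and "the series" means these compounds.

Measured compounds:
- compound 1, `CN(C)CCCNc1nc(-c2ccc(NC(=O)Nc3ccc(Cl)cc3Cl)cc2)nc2ccsc12`, 1860 nM
- compound 2, `CN(C)CCCNc1nc(-c2ccc(NC(=O)Nc3ccccc3Cl)cc2)nc2c(Cl)c(Cl)sc12`, 1560 nM
- compound 3, `CN(C)CCNc1nc(-c2ccc(NC(=O)Nc3ccccc3)cc2)nc2ccsc12`, 1310 nM

The three compounds share a core and were tested in a functional assay on MDA-MB-231 cells (Homo sapiens) for cytotoxicity, read by MTT assay, with a stated time of 72 h; on this read-out higher numbers stand for weaker inhibition and lower numbers for stronger inhibition. Compound 3 carries the lowest number of the three, but its values against compound 2 and against compound 1 both fall within the usual scatter of such measurements, so nothing can be said about an order among them. All three compounds give numbers of about the same size.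

Compound 4 is `CN(C)CCNc1nc(-c2ccc(NC(=O)Nc3ccccc3F)cc2)nc2ccsc12`. It differs from compound 3 in one place: fluoro in place of hydrogen on an aromatic carbon. Going by the values given here, no pair of measured compounds differs by only such a change, so there is no measured step to lean on. Given that the change is a single small atom in place of a hydrogen on the outer phenyl ring, and that the three measured compounds all lie within the scatter of one another despite larger differences, the step from compound 3 to compound 4 is expected to be small, a 1.1-fold lower number from compound 3 to compound 4 (0.04 log units; within the scatter), not beyond the scatter in either direction. Compound 4 is therefore expected to give about 1200 nM in this assay, with a likely range from 500 nM to 3000 nM.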

Compound 4, half-maximal inhibitory concentration: 600 nM
Compound 4: middle estimate off by 2.0-fold (0.30 log units), on the high side, and the stated range covers the measured number.
By their numbers in this assay, from the lowest: compound 4; then compounds 3, 2 and 1 (each within the scatter of the next).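

Placing one fluoro on the outer phenyl ring, ortho to a large group, gives a 2.2-fold lower number from compound 3 to compound 4 (0.34 log units; beyond the scatter) in this assay. Going by these compounds alone, this is the first step here that can be read across a single change, and it lies beyond the scatter, whereas the earlier compounds differ from one another in more than one place and their values stay within the scatter. It shows that this position on the ring, at the far end of the urea, can register a swap as small as hydrogen to fluoro, although the step is modest in size. Nothing available explains why the number falls with this change.

From the compounds shown here alone, whether methyl, methoxy or trifluoromethyl at this same place would lower the number further, leave it alone or raise it remains open, as does the effect of fluoro at other places on this ring. Also open, going by these compounds, is whether the same change would give a similar step on the dimethylaminopropyl side chain of compound 1, or in any cell line other than this one.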